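Phenoxy substitution and cytotoxicity in the quinazoline-free shared core

The source may hold more compounds than are shown below. What is called first, only, known or untested is meant among the compounds shown, and "the series" means these compounds.

Measured compounds:
compound 1 `COc1cc(C#N)ccc1Oc1nc(Nc2ccc(C#N)cc2)nc2ccccc12`: >= 140000 nM
compound 2 `N#Cc1ccc(Nc2nc(Oc3ccc(Br)cc3)c3ccccc3n2)cc1`: 215000 nM
compound 3 `N#Cc1ccc(Nc2nc(Oc3ccccc3)c3ccccc3n2)cc1`: 370000 nM

In an ADME assay on MT4 cells (Homo sapiens) for cytotoxicity, read by MTT assay, with a stated time of 4 days (a higher number here means that more compound is tolerated, a lower number that less compound is tolerated), compound 3 gives 370000 nM, the highest of the two numbers present; its nearest neighbour is compound 2, and the step of a 1.7-fold higher number from compound 2 to compound 3 (0.24 log units; within the scatter) lies within the scatter. For compound 1 the value is a limit of the assay and not a number (the limit of >= 140000 nM in this assay, at which 1 of the 3 values shown sits). The steps a step that the limit leaves unreadable from compound 1 to compound 2 and a step that the limit leaves unreadable from compound 1 to compound 3 therefore cannot be sized.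

Compound 4 `Cc1ccccc1Oc1nc(Nc2ccc(C#N)cc2)nc2ccccc12` is not yet measured. It differs from compound 3 in one place: methyl in place of hydrogen on an aromatic carbon. Among the compounds with values here, the only readable step, a 1.7-fold higher number from compound 2 to compound 3 (0.24 log units; within the scatter), concerns a different exchange on the same phenoxy ring and stayed within the scatter. Within the data shown here, nothing among the measured steps shows a change in this assay from a substituent on this ring that is beyond the scatter. For compound 4 the step of a 1.2-fold lower number from compound 3 to compound 4 (0.09 log units; within the scatter) is therefore expected to be no larger than the scatter. Compound 4 is estimated at 300000 nM, with a range from 150000 nM to 600000 nM.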

Compound 4, half-maximal cytotoxic concentration: 355000 nM
Estimate against measurement, compound 4: 1.2-fold (0.07 log units) below; the range from low to high includes it.
By their numbers in this assay, from the lowest: compounds 2, 4 and 3 (each within the scatter of the next).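

Methyl in place of hydrogen on the phenoxy ring, ortho to a large group, gives in this assay a 1.0-fold lower number from compound 3 to compound 4 (0.02 log units; within the scatter), so this position now has a reading of its own and a methyl there leaves no readable change. The exchange of 4-bromophenyl for 2-methylphenyl on the oxygen gives a 1.7-fold higher number from compound 2 to compound 4 (0.22 log units; within the scatter), so phenoxy, 4-bromophenoxy and 2-methylphenoxy cannot be told apart in this read-out. The steps from compound 1 cannot be read because its value is a limit of the assay and not a number: the limit of >= 140000 nM in this assay, at which 1 of the 4 values shown sits.

Going by these compounds, whether an amine, a carboxylic acid or a longer chain at this position would give a step beyond the scatter remains open. Also open, on these data alone, is whether a methyl elsewhere on the phenoxy ring would read the same.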